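A few compounds are considered here, and "the series" means these few. Any claim that something is new, unique, unknown or untested is made for them only; others in the source may bear on it.

Measured in a functional assay on HEp-2 cells (Homo sapiens) for inhibition; on this read-out higher numbers stand for an effect only at larger amounts of compound and lower numbers for an effect already at smaller amounts:

- compound 1 `CSc1ncnc2c1nnn2[C@@H]1O[C@H](CO)[C@@H](O)[C@H]1O`: 0.02 uM
- compound 2 `CCSc1ncnc2c1nnn2[C@@H]1O[C@H](CO)[C@@H](O)[C@H]1O`: 0.1 uM
- compound 3 `CCCCNc1ncnc2c1nnn2[C@@H]1O[C@H](CO)[C@@H](O)[C@H]1O`: 0.3 uM

Among these three, compound 3 has the highest number, at 0.3 uM, so it needs the largest amount for its effect. The next structure, compound 4 `OC[C@H]1O[C@@H](n2nnc3c(S)ncnc32)[C@H](O)[C@@H]1O`, carries sulfanyl in place of butylamino on an aromatic carbon.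

Among the measured compounds shown here, two measured steps bear most directly on this exchange, since each sets a sulfur-linked group against butylamino. They are a 15-fold higher number from compound 1 to compound 3 (1.18 log units; beyond the scatter) and a 3.0-fold higher number from compound 2 to compound 3 (0.48 log units; beyond the scatter). Both lie beyond the scatter, and in both the butylamino compound has the higher number. Read in reverse, they suggest that leaving butylamino for a sulfur-linked group lowers the number.

A third step, a 5.0-fold higher number from compound 1 to compound 2 (0.70 log units; beyond the scatter), shows that the number is sensitive to the chain on sulfur. For the measured compounds named here, compound 4 has no such chain, however, and no measured compound carries a free sulfanyl group, so the size of the change is poorly defined. A modest fall in this assay is therefore expected, with a wide margin.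

The expected change is a 2.0-fold lower number from compound 3 to compound 4 (0.30 log units; within the scatter). For compound 4 the estimated value is 0.15 uM, with an expected range of 0.015 uM to 2 uM.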

Compound 4, concentration for half-maximal effect: 1 uM
Compound 4: middle estimate off by 6.7-fold (0.82 log units), on the low side, and the stated range covers the measured number.
By their numbers in this assay, from the lowest: compound 1; then compound 2; then compound 3; then compound 4.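

In this assay, the free sulfanyl group breaks from the two compounds with a chain on sulfur (a 3.3-fold higher number from compound 3 to compound 4 (0.52 log units; beyond the scatter)), so a sulfur-linked group on this aromatic carbon does not by itself give a lower number than butylamino. The hydrogen on sulfur matters most when set against the chains it replaces (a 10-fold higher number from compound 2 to compound 4 (1.00 log units; beyond the scatter); a 50-fold higher number from compound 1 to compound 4 (1.70 log units; beyond the scatter)), and the sulfur series does not run in order of chain size: methyl gives the lowest number, ethyl a higher one and hydrogen the highest of the four compounds. No measurement at hand accounts for this rise on losing the chain from sulfur.

The compounds shown leave open whether a longer chain on sulfur, such as propyl or butyl, would raise the number further beyond that of ethyl, and whether butylsulfanyl would stand above or below butylamino. They also leave open how a shorter nitrogen-linked group, such as methylamino or a free amine, would compare with methylsulfanyl at this same position.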